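The compounds below may be only part of what the source reports. "The series", "measured", "known", "first", "only" and "open" are said of these compounds alone.

Compound 1, `CC(C)=C(C)C#Cc1ccc(CCC(=O)O)cc1`, gives 83.2 nM in a functional assay on 1321-N1 cells for agonist activity at Free fatty acid receptor 1 (Homo sapiens), read by calcium flux, with a stated time of 0.4 s; on this read-out lower numbers stand for an effect already at smaller amounts and higher numbers for an effect only at larger amounts of compound. Compound 2, `C=C(C)C#Cc1ccc(CCC(=O)O)c(F)c1`, gives 81.3 nM. Compound 3, `O=C(O)CCc1ccc(C#CC2CCCCC2)cc1`, gives 513 nM.

Among the three measured compounds, compound 3 stands with the highest number. Its distance from compound 1 is the step of a 6.2-fold higher number from compound 1 to compound 3 (0.79 log units; beyond the scatter), and compound 2 lies about as far below compound 3 as compound 1 does, so compound 3 is clearly the weakest of the set on this read-out.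

The next compound, compound 4, `C=C(C)C#Cc1ccc(CCC(=O)O)cc1`, is reached from compound 3 by a change at the far end of the triple bond: 1-methylethenyl in place of cyclohexyl on a triple-bonded carbon. Within the data shown here, only one measured step speaks to this change, and it runs the opposite way. Going from compound 1 to compound 3 replaced an open-chain alkenyl group with cyclohexyl, and the number rose by a 6.2-fold higher number from compound 1 to compound 3 (0.79 log units; beyond the scatter). Compound 4 reverses that kind of exchange, putting an open-chain alkenyl group back in place of cyclohexyl, so a drop of roughly the same size is the natural expectation. Compound 2, which carries the same 1-methylethenyl group on a core that also bears fluorine, gives 81.3 nM, which points the same way.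

Compound 4 is therefore expected to give about 100 nM in this assay, with a likely range from 40 nM to 250 nM. For compound 4 this amounts to an expected step of a 5.1-fold lower number from compound 3 to compound 4 (0.71 log units; beyond the scatter).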

Compound 4, half-maximal effective concentration: 417 nM
Compound 4: the middle estimate sits 4.2-fold (0.62 log units) below what was measured; the measured number lies above the stated range.
By their numbers in this assay, from the lowest: compounds 2 and 1 (each within the scatter of the next); then compounds 4 and 3 (each within the scatter of the next).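

Putting 1-methylethenyl in place of cyclohexyl on a triple-bonded carbon gives a 1.2-fold lower number from compound 3 to compound 4 (0.09 log units; within the scatter) in this assay, so this exchange alone does not separate the two compounds, and an open-chain group with a double bond is not enough to reach the low numbers seen earlier. The other two steps show that the 1-methylethenyl group gives a low number only in particular company: hydrogen in place of fluoro on an aromatic carbon gives a 5.1-fold higher number from compound 2 to compound 4 (0.71 log units; beyond the scatter), and 1-methylethenyl in place of 1,2-dimethylprop-1-en-1-yl gives a 5.0-fold higher number from compound 1 to compound 4 (0.70 log units; beyond the scatter). Nothing available here explains why either of these two exchanges matters while the exchange with cyclohexyl does not.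

On these data alone, the effect of fluoro rests on this single pair, so it remains open whether fluoro on an aromatic carbon would give a similar step with cyclohexyl or 1,2-dimethylprop-1-en-1-yl at the end of the triple bond. As far as these compounds go, it is also open how chloro or methyl would compare with fluoro on that carbon, and how a longer alkyl chain would compare with these groups on the triple-bonded carbon.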